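Chlorophenyl Replacing Indole on a Shared Core

This account rests on a few compounds, and the source may have more. Where it says the series, first, only, none or still open, it means among the compounds named here.

The study covers three measured compounds built on one shared core. Compound 1 `CC(=O)Nc1cccc(-c2ccc(C(=O)N(Cc3cccc(OCCCCCC(=O)O)c3)C(C)C)cc2)c1` carries an acetamido group, compound 2 `CC(C)N(Cc1cccc(OCCCCCC(=O)O)c1)C(=O)c1ccc(-c2cccc(Oc3ccccc3)c2)cc1` a phenoxy group, and compound 3 `CC(C)N(Cc1cccc(OCCCCCC(=O)O)c1)C(=O)c1ccc(-c2ccc3cc[nH]c3c2)cc1` an indole. In an ADME assay on HepG2 cells (Homo sapiens) for cytotoxicity, read by CellTiter-Glo and resazurin assay, with a stated time of 72 h (on this read-out higher numbers stand for an effect only at larger amounts of compound and lower numbers for an effect already at smaller amounts), compound 1 gives > 26000 nM, which is a limit of the assay rather than a number. In this assay compound 2 gives > 18700 nM, again only a limit. In this assay compound 3 gives > 26000 nM, likewise a limit. The two measured steps are therefore a step that the two limits leave unreadable from compound 1 to compound 2 and a step that the two limits leave unreadable from compound 1 to compound 3, neither of which can be read as a size. Among the compounds with values here, compound 3 thus stands at the limit of > 26000 nM in this assay, at which 2 of the 3 values shown sit, the same limit as compound 1, while compound 2 sits at the limit of > 18700 nM in this assay, at which 1 of the 3 values shown sits; no compound among the three shows a numerical value, so none can be ranked against another.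

Compound 4 `CC(C)N(Cc1cccc(OCCCCCC(=O)O)c1)C(=O)c1ccc(-c2cccc(Cl)c2)cc1` is the next compound, and its change from compound 3 is 3-chlorophenyl in place of 1H-indol-6-yl on an aromatic carbon. Both measured steps bear on this change only insofar as each replacement on the same aromatic carbon left the value at a limit, so no step beyond the scatter is expected in this assay. The estimate for compound 4 is 26000 nM, expected to lie between 12000 nM and 55000 nM. The step of a number no higher from compound 3 to compound 4 (the limit leaves the size open) is accordingly expected to be negligible.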

Compound 4, half-maximal effective concentration: > 21900 nM
Compound 4: only a limit was reported; the forecaster's own chance of this, stated with the estimate: 80%; the middle value lies beyond the limit too.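

Compound 4 is reported only as a limit in this assay, as are compound 1, compound 2 and compound 3, so the steps from each of them to compound 4 cannot be read as sizes. The compounds shown leave open whether any of these groups on the shared core differs from another in this assay.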